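Fluoro in Place of Trifluoromethyl on the Shared Core

A few compounds are considered here, and "the series" means these few. Any claim that something is new, unique, unknown or untested is made for them only; others in the source may bear on it.

Measured compounds:
- Compound 1 `COC(=O)N[C@H](C(=O)N1CCC[C@H]1C(=O)Nc1ccc([C@H]2CC[C@H](c3ccc(NC(=O)[C@@H]4CCCN4C(=O)[C@@H](NC(=O)OC)C(C)C)cc3)N2c2ccc(C(F)(F)F)cc2)cc1)C(C)C` gives 13% in an ADME assay on the whole organism for pharmacokinetics, with Rattus norvegicus as the target, at a dose of 3 mg/kg by the oral route; a higher number here means that a larger share of the oral dose reaches the circulation, a lower number that a smaller share of the oral dose reaches the circulation.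
- Compound 2 `COC(=O)N[C@H](C(=O)N1CCC[C@H]1C(=O)Nc1ccc([C@@H]2CC[C@@H](c3ccc(NC(=O)[C@@H]4CCCN4C(=O)[C@@H](NC(=O)OC)[C@@H](C)OC)cc3)N2c2ccc(F)cc2)cc1)[C@@H](C)OC` gives 14% in this assay.
- Compound 3 `COC(=O)N[C@H](C(=O)N1CCC[C@H]1C(=O)Nc1ccc([C@H]2CC[C@H](c3ccc(NC(=O)[C@@H]4CCCN4C(=O)[C@@H](NC(=O)OC)[C@@H](C)OC)cc3)N2c2ccc(F)cc2)cc1)[C@@H](C)OC` gives 15% in this assay.

The three numbers lie close together: compound 1 sits no further from compound 2 or from compound 3 than the usual scatter of repeated measurements, so none of the three stands apart from the others.

Compound 4 `COC(=O)N[C@H](C(=O)N1CCC[C@H]1C(=O)Nc1ccc([C@H]2CC[C@H](c3ccc(NC(=O)[C@@H]4CCCN4C(=O)[C@@H](NC(=O)OC)C(C)C)cc3)N2c2ccc(F)cc2)cc1)C(C)C` differs from compound 1 in one place: fluoro in place of trifluoromethyl on an aromatic carbon.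

Only one measured step exists among these compounds, a number 1 percentage points higher from compound 2 to compound 3 (within the scatter), and it rests on (the fact that compounds 2 and 3 differ only in the configuration as drawn). Among the compounds with values here, that step therefore tells nothing about a change of the group on the aromatic ring, and no measured step bears directly on the move from compound 1 to compound 4. All that can be drawn on is that the three measured numbers, across different side chains and configurations, stay within the scatter of one another.

On that basis a step within the scatter is expected in this assay, namely a number 1 percentage points higher from compound 1 to compound 4 (within the scatter). Compound 4 is thus estimated at 14%, with a range from 5% to 28%.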

Compound 4, oral bioavailability in the Rattus norvegicus assay: 22%
The estimate for compound 4 lay 8 percentage points below the measured number; measured number inside the range.
By their numbers in the Rattus norvegicus assay, from the lowest: compounds 1, 2, 3 and 4 (each within the scatter of the next).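

Within the data shown here, this is the first reading of a change at this position, the aromatic carbon para to a large group: the only earlier step concerned configuration, whereas here 4-(trifluoromethyl)phenyl in compound 1 becomes 4-fluorophenyl in compound 4 with the rest of the compound untouched, and in a physicochemical assay for solubility, in phosphate buffer, measured as kinetic solubility, at pH 7.2 (on this read-out higher numbers stand for higher solubility and lower numbers for lower solubility), compound 1 gives 3200 nM and compound 4 gives 6000 nM. In the Rattus norvegicus assay the exchange gives a number 9 percentage points higher from compound 1 to compound 4 (within the scatter), and in the physicochemical assay it gives a 1.9-fold higher number from compound 1 to compound 4 (0.27 log units; within the scatter), so neither read-out separates the two compounds beyond the usual scatter, and the position accepts fluoro as well as trifluoromethyl without a loss on either measure. The information at hand offers no explanation of how this group exchange acts on either read-out.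

The compounds shown leave open whether a different group on this aromatic carbon, such as chloro, a nitrile, an amine or a carboxylic acid, would move either read-out beyond the scatter. They also leave open whether the exchange of trifluoromethyl for fluoro would read the same way on the other side chains, those carried by compound 2 and compound 3.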